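Methoxy to Chloro on the Benzyl Core: Solubility Notes

The compounds below may be only part of what the source reports. "The series", "measured", "known", "first", "only" and "open" are said of these compounds alone.

Working notes on a small set of compounds measured in a physicochemical assay for solubility, read by HPLC, at pH 7.4; a higher number here means a more soluble compound, a lower number a less soluble compound.

Compound 1 `COc1ccc2[nH]c(C)c(Br)c(=O)c2c1` returns only a limit of this assay, > 20000 nM, at the limit of > 20000 nM in this assay, at which 1 of the 3 values shown sits. Compound 2 `Cc1[nH]c2ccc(Cl)cc2c(=O)c1Br` gives 5000 nM in this assay, and the step of an at least 4.0-fold lower number from compound 1 to compound 2 (0.60 log units; beyond the scatter) goes with the change (chloro in place of methoxy on an aromatic carbon). Among the measured compounds shown here, compound 3 `COc1ccc2[nH]c(C)c(Cc3ccccc3)c(=O)c2c1` gives 2000 nM in this assay, the lowest of the two numbers so far, with the step of an at least 10-fold lower number from compound 1 to compound 3 (1.00 log units; beyond the scatter) going with the change (benzyl in place of bromo on an aromatic carbon); this last change is also how the core of compound 3 and compound 4 differs from the core of compound 1 and compound 2.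

Compound 4 `Cc1[nH]c2ccc(Cl)cc2c(=O)c1Cc1ccccc1` has not yet been measured in this assay. It differs from compound 3 by chloro in place of methoxy on an aromatic carbon. This is the same change made from compound 1 to compound 2; it occurs two times among the compounds here, and the two places agree word for word. The step from compound 3 to compound 4 in this assay is therefore expected to be about a 4.0-fold lower number from compound 3 to compound 4 (0.60 log units; beyond the scatter), resting on the measured step of an at least 4.0-fold lower number from compound 1 to compound 2 (0.60 log units; beyond the scatter), with the note that the earlier step starts from a limit and so gives only a floor on its size. Compound 4 is expected to give about 500 nM in this assay, most likely between 150 nM and 2000 nM.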

Compound 4, solubility: < 2000 nM
Compound 4 was reported as a limit; the forecaster's own chance of this, stated with the estimate: 10%; the middle value lies beyond the limit too.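

In this assay compound 4 is reported only as a limit, and this is the whole of the new result: the limit of < 2000 nM in this assay, at which 1 of the 4 values shown sits. Carried from the core of compound 1 to the core of compound 3, chloro in place of methoxy on an aromatic carbon gives a number no higher from compound 3 to compound 4 (the limit leaves the size open), which does not go against the direction of an at least 4.0-fold lower number from compound 1 to compound 2 (0.60 log units; beyond the scatter), but it does not show that the size of the step carries from one core to the other, or even that any change took place on the second core. The earlier step offers only a floor for such a comparison, since it starts from compound 1, which is also only a limit: the limit of > 20000 nM in this assay, at which 1 of the 4 values shown sits.

Among the compounds shown here, the two cores therefore give no pair in which both ends of this change are numbers, and whether the step has a similar size on both cores stays open. Also open, going by these compounds, is how this assay would read with an amine or a carboxylic acid on the aromatic carbon that carries methoxy or chloro, or with a longer chain in the place held by bromo or benzyl.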